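The source may report more compounds than this note shows. Statements on the series, on what has been measured and on what is new or still open speak of the compounds shown alone.

In a functional assay on LoVo cells (Homo sapiens) for inhibition, read by MTT assay, with a stated time of 24 h (on this read-out higher numbers stand for weaker inhibition and lower numbers for stronger inhibition), compound 3 `CC1(C)[C@H]2CC[C@]1(C)N(Cc1cn(-c3ccc(C#N)cc3)nn1)C(=O)C2` gives 90 nM, the lowest of the three numbers measured. Its nearest neighbour is compound 1 `CC1(C)[C@H]2CC[C@]1(C)N(Cc1cn(-c3ccc(Cl)cc3)nn1)C(=O)C2`, which in this assay gives 160 nM; the step of a 1.8-fold lower number from compound 1 to compound 3 (0.25 log units; within the scatter) lies within the scatter, so the two cannot be ranked. Compound 2 `CC1(C)[C@H]2CC[C@]1(C)N(Cc1cn(-c3ccccc3O)nn1)C(=O)C2` stands furthest away with 540 nM, and the step of a 6.0-fold lower number from compound 2 to compound 3 (0.78 log units; beyond the scatter) is beyond the scatter.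

Compound 4 `CC1(C)[C@H]2CC[C@]1(C)N(Cc1cn(-c3cccc(C#N)c3)nn1)C(=O)C2` differs from compound 3 only in the position of the nitrile on the phenyl ring: 3-cyanophenyl in place of 4-cyanophenyl on an aromatic nitrogen. For the measured compounds named here, no measured step moves a group around the phenyl ring while keeping it otherwise the same. The step of a 3.4-fold higher number from compound 1 to compound 2 (0.53 log units; beyond the scatter) exchanges both the group and its place, and the step of a 1.8-fold lower number from compound 1 to compound 3 (0.25 log units; within the scatter) changes only the group, so neither bears directly on this move. Going by the values given here, with no direct precedent, a step of modest size at most is expected, and its direction is uncertain.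

The expected step of a 1.6-fold higher number from compound 3 to compound 4 (0.19 log units; within the scatter) is therefore a small one. Compound 4 is estimated at 140 nM in this assay, within a range from 50 nM to 400 nM.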

Compound 4, half-maximal inhibitory concentration: 320 nM
Beside the measured number, compound 4's estimate is 2.3-fold (0.36 log units) below it; the range from low to high includes it.
By their numbers in this assay, from the lowest: compounds 3, 1, 4 and 2 (each within the scatter of the next, the first and the last beyond it).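

For the compounds shown here, compound 3 and compound 4 give the first pair in which the group stays the same and only its place on the phenyl ring changes, and in this assay that alone is enough to move the result: a 3.6-fold higher number from compound 3 to compound 4 (0.55 log units; beyond the scatter). The place of the nitrile thus matters on this phenyl ring on an aromatic nitrogen, yet 3-cyanophenyl cannot be ranked against either 2-hydroxyphenyl, with a 1.7-fold lower number from compound 2 to compound 4 (0.23 log units; within the scatter), or 4-chlorophenyl, with a 2.0-fold higher number from compound 1 to compound 4 (0.30 log units; within the scatter). No measurement available here accounts for the shift.

The compounds shown leave open whether 3-chlorophenyl would stand to 4-chlorophenyl as 3-cyanophenyl stands to 4-cyanophenyl. They also leave open how an amine or a carboxylic acid would fare in place of the nitrile in 4-cyanophenyl.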